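Chloro added to a cyclopropyl amide of compound 3's series

A few compounds are considered here, and "the series" means these few. Any claim that something is new, unique, unknown or untested is made for them only; others in the source may bear on it.

Measured compounds in a toxicity assay on the whole organism (strain Icem-CET (SPF Caw)) for cytotoxicity, with Mus musculus as the target; a higher number here means that more compound is needed for the effect, a lower number that less compound is needed: compound 1 `C=CCNC(=O)/C(C)=C(/C)c1ccc(Cl)cc1` gives 180 mg/kg; compound 2 `C=CCNC(=O)/C(C)=C(/C)c1ccccc1` gives 550 mg/kg; compound 3 `C/C(C(=O)NC1CC1)=C(\C)c1ccccc1` gives 400 mg/kg.

Compound 4 `C/C(C(=O)NC1CC1)=C(\C)c1ccc(Cl)cc1` has not yet been measured in this assay. Compound 4 differs from compound 3 by chloro in place of hydrogen on an aromatic carbon. The same change has already been made once among these compounds, from compound 2 to compound 1, as chloro in place of hydrogen on an aromatic carbon, where it gave a 3.1-fold lower number from compound 2 to compound 1 (0.49 log units; beyond the scatter). The core of compound 3 differs from that of compound 2 by cyclopropyl in place of allyl on an amide-type nitrogen, a change that made a 1.4-fold lower number from compound 2 to compound 3 (0.14 log units; within the scatter).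

Because the chloro step gave a 3.1-fold lower number from compound 2 to compound 1 (0.49 log units; beyond the scatter) on the core of compound 2, a step of similar size is expected on the core of compound 3, so compound 4 is estimated to show a 2.9-fold lower number from compound 3 to compound 4 (0.46 log units; beyond the scatter). This rests on a single precedent, so the range is kept wide. Compound 4 is therefore expected to give about 140 mg/kg, likely between 70 mg/kg and 280 mg/kg.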

Compound 4, dose for half-maximal effect: 170 mg/kg
Compound 4: middle estimate off by 1.2-fold (0.08 log units), on the low side; low and high end bracket the measured number.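

In this assay, chloro in place of hydrogen on an aromatic carbon gave a 2.4-fold lower number from compound 3 to compound 4 (0.37 log units; beyond the scatter), so the step carried over to the cyclopropyl amide at a matching size: the same change on two cores in this assay, a 3.1-fold lower number (0.49 log units; beyond the scatter) from compound 2 to compound 1 and a 2.4-fold lower number (0.37 log units; beyond the scatter) from compound 3 to compound 4, 1.3-fold (0.11 log units) apart, within the scatter of two such steps. Cyclopropyl in place of allyl gave a 1.1-fold lower number from compound 1 to compound 4 (0.02 log units; within the scatter) with chloro present, and this step also held across the two cores: the same change on two cores in this assay, a 1.4-fold lower number (0.14 log units; within the scatter) from compound 2 to compound 3 and a 1.1-fold lower number (0.02 log units; within the scatter) from compound 1 to compound 4, 1.3-fold (0.11 log units) apart, within the scatter of two such steps. This shows that the two changes behaved alike across these four compounds, but two cores cannot show that this would hold on other cores, and the data do not explain why chloro has this effect.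

From the compounds shown here alone, whether fluoro, methoxy or a nitrile in the place of chloro would give a similar step remains open. So does the effect of a longer chain on the amide nitrogen.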